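The source may hold more compounds than are shown below. What is called first, only, known or untested is meant among the compounds shown, and "the series" means these compounds.

Measured so far:
- compound 1, `N#CN/C(=N\CC1CCCO1)Nc1cccnc1` — in a functional assay on the whole organism (blood, strain Wistar-Okamoto) with Rattus norvegicus as the target, with a stated time of 5 days (on this read-out higher numbers stand for an effect only at larger amounts of compound and lower numbers for an effect already at smaller amounts), compound 1 gives 50 mg/kg
- compound 2, `CCOC(=O)/N=C(/Nc1cccnc1)NC(C)(C)CC` — in this assay compound 2 gives 20 mg/kg

Compound 2 stands at the lower of the two numbers; the gap to compound 1 lies beyond the usual scatter, so compound 2 is the one acting at the smaller amount among the two measured. Going by the values given here, both compounds share a core of the same kind, and the only change tried so far is read from their values alone, with no single-point comparison available between them.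

Compound 3, `CCC(C)(C)N/C(=N\c1ncccn1)Nc1cccnc1`, is the next candidate. Its difference from compound 2 is pyrimidin-2-yl in place of ethoxycarbonyl on a double-bonded nitrogen. No comparison of this kind has been measured in the series, so the direction of the step is open. With the pyrimidin-2-yl group keeping the count of hydrogen-bond acceptors unchanged and the rest of compound 2 retained, the expectation is a step from compound 2 to compound 3 of a 1.3-fold higher number from compound 2 to compound 3 (0.10 log units; within the scatter) in this assay, that is, nothing clearly beyond the scatter. Compound 3 is accordingly estimated at 25 mg/kg, within a range from 6 mg/kg to 100 mg/kg.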

Compound 3, minimum effective dose: > 35 mg/kg
Compound 3 was reported as a limit (the forecaster's own chance of this, stated with the estimate: 15%); middle value at least 1.4-fold (0.14 log units) away from the limit.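

Going by these compounds alone, this is the first comparison that differs in one place: pyrimidin-2-yl in place of ethoxycarbonyl on a double-bonded nitrogen gives an at least 1.7-fold higher number from compound 2 to compound 3 (0.24 log units; that floor lies within the scatter). Compound 3 gives > 35 mg/kg in this assay, which is a limit of the assay and not a number. On this read-out, the exchange of the open-chain ethoxycarbonyl for the six-membered aromatic ring brings no lower number at this position, yet the floor of the step alone does not place the change beyond the scatter, and the reading rests on a single censored value: the limit of > 35 mg/kg in this assay, at which 1 of the 3 values shown sits.

Open, from the compounds shown here alone, is how far the true value of compound 3 lies from the limit, and so whether this change at the double-bonded nitrogen has a real effect on the minimum effective dose or none beyond the scatter. Also open, going by these compounds, is how other groups at the same place, such as methylsulfonyl or carbamoyl, would read against ethoxycarbonyl with the rest of compound 2 kept unchanged.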